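The source may report more compounds than this note shows. Statements on the series, on what has been measured and on what is new or still open speak of the compounds shown alone.

Of the compounds shown here, three of one shared core have been measured in an assay on cells for inhibition of cytochrome P450 11B2, mitochondrial (Homo sapiens), read by HTRF; a lower number here means a stronger inhibitor, a higher number a weaker inhibitor. Compound 1, `C[C@@H](NS(C)(=O)=O)c1cncc(N2C(=O)c3ccc(Cl)cc3C2(C)C)c1`, gives 8 nM there and stands second highest of the three numbers. Its nearest neighbour is compound 3, `CCC(=O)N[C@@H]1CCCc2c1cncc2N1C(=O)c2ccc(Cl)cc2[C@@H]1CC`, which gives 12 nM; the gap between the two lies within the scatter. The furthest is compound 2, `CCS(=O)(=O)N1CC(Oc2cncc(N3C(=O)c4ccc(Cl)cc4C3(C)C)c2)C1`, which gives 4 nM; that gap too lies within the scatter, so the three cannot be ranked against each other.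

The step now followed leads from compound 1 to compound 4, `CCS(=O)(=O)NCc1cncc(N2C(=O)c3ccc(Cl)cc3C2(C)C)c1`, which has not yet been measured in this assay. The two have the same atoms, joined differently: a group of 7 heavy atoms (3 carbon, 1 nitrogen, 2 oxygen, 1 sulfur; no ring) in place of a group of 7 heavy atoms (3 carbon, 1 nitrogen, 2 oxygen, 1 sulfur; no ring), on an aromatic carbon The change sits on an aromatic carbon of a six-membered aromatic ring with 1 nitrogen, two atoms from the ring nitrogen, and the stereocentre of compound 1 is lost while a group of the same make-up and the same donor and acceptor count enters.

Because compound 1 gives 8 nM and nothing among the three measured compounds separates beyond the scatter, the expected step from compound 1 to compound 4 is small, a 1.5-fold higher number from compound 1 to compound 4 (0.18 log units; within the scatter), and not clearly beyond the scatter in either direction. The estimate for compound 4 in this assay is 12 nM, with a range from 5 nM to 30 nM.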

Compound 4, half-maximal inhibitory concentration: 92 nM
The estimate for compound 4 lay 7.7-fold (0.88 log units) below the measured number; the whole stated range lies below it.
By their numbers in this assay, from the lowest: compounds 2, 1 and 3 (each within the scatter of the next, the first and the last beyond it); then compound 4.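

In this assay, the place two atoms from the ring nitrogen proves sensitive to how a group's atoms are joined: putting ((ethylsulfonyl)amino)methyl in place of the group with the defined stereocentre gives a 12-fold higher number from compound 1 to compound 4 (1.06 log units; beyond the scatter). For the compounds shown here, the three earlier compounds differ from each other in more than one place, so only this step shows that the same atoms, with the same hydrogen-bond donor and acceptor counts, do not guarantee similar inhibition here. Nothing measured here explains the weaker inhibition.

On these data alone, this single step changes the way the atoms are joined and removes the stereocentre together, so the share of each stays open. It also leaves open how a group without the sulfonyl part, such as a simple aminomethyl or a carboxylic acid, would fare at this place.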